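Ether Oxygen Returns Beside Added Bulk at the Aryloxy Carbon

This account rests on a few compounds, and the source may have more. Where it says the series, first, only, none or still open, it means among the compounds named here.

Measured compounds:
compound 1 `COCC(C)Oc1cccc2ccc(N)nc12` with 606 nM
compound 2 `CCC(CC)C(C)Oc1cccc2ccc(N)nc12` with 191 nM
compound 3 `CC(C)C(C)Oc1cccc2ccc(N)nc12` with 199 nM

In an assay on cells with melanin-concentrating hormone receptor 1 (Homo sapiens) as the target, read by radioligand binding (a lower number here means a stronger inhibitor, a higher number a weaker inhibitor), compound 3 stands second highest of the three numbers; its nearest neighbour is compound 2, the difference a 1.0-fold higher number from compound 2 to compound 3 (0.02 log units; within the scatter) lying within the scatter, while the gap to compound 1, a 3.0-fold lower number from compound 1 to compound 3 (0.48 log units; beyond the scatter), is beyond it.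

Compound 4 `CC(COC(C)(C)C)Oc1cccc2ccc(N)nc12` carries the change ((tert-butoxy)methyl in place of isopropyl on a saturated chain carbon bound to an oxygen on an aromatic ring and a saturated chain carbon). Going by the values given here, two measured steps bear on it. The step of a 3.2-fold lower number from compound 1 to compound 2 (0.50 log units; beyond the scatter) and the step of a 3.0-fold lower number from compound 1 to compound 3 (0.48 log units; beyond the scatter) both show that exchanging methoxymethyl for a plain branched alkyl group lowers the number modestly. Compound 4 reverses part of that: an ether oxygen enters again, as in compound 1, but inside a larger (tert-butoxy)methyl group, so the measured data point in two directions at once. The step of a 1.8-fold higher number from compound 3 to compound 4 (0.25 log units; within the scatter) is therefore expected to be a modest rise, smaller than the return to compound 1. Compound 4 is estimated at 350 nM in this assay, with a range from 150 nM to 900 nM.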

Compound 4, half-maximal inhibitory concentration: 306 nM
The estimate for compound 4 lay 1.1-fold (0.06 log units) above the measured number; the range from low to high includes it.
By their numbers in this assay, from the lowest: compounds 2, 3, 4 and 1 (each within the scatter of the next, the first and the last beyond it).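

In this assay, the step of a 1.5-fold higher number from compound 3 to compound 4 (0.19 log units; within the scatter) and the step of a 1.6-fold higher number from compound 2 to compound 4 (0.20 log units; within the scatter) both leave compound 4 unresolved from the two compounds with plain branched alkyl groups. The step of a 2.0-fold lower number from compound 1 to compound 4 (0.30 log units; within the scatter) leaves it equally unresolved from the methoxymethyl compound, so tert-butyl in place of methyl on an oxygen on a saturated carbon produces no readable change. Although compound 1 is separated beyond the scatter from compound 2 and from compound 3, compound 4 shows that a group with an ether oxygen at this place need not be separated from them.

No measurement shown explains these numbers or accounts for the position of compound 4 among them. From the compounds shown here alone, it remains open whether a hydroxymethyl or aminomethyl group on this saturated chain carbon would give a number that stands clearly apart from those of compound 1 or of compounds 2 and 3.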